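Nitrophenyl for Cyanophenyl on Two Related Cores

The source may hold more compounds than are shown below. What is called first, only, known or untested is meant among the compounds shown, and "the series" means these compounds.

In a functional assay on DU-145 cells (Homo sapiens) for cytotoxicity, read by MTT assay, with a stated time of 48 h (on this read-out lower numbers stand for stronger inhibition and higher numbers for weaker inhibition), the three measured compounds stand as follows:
compound 1, `CC(C)=CCC/C(C)=C/CC/C(C)=C/CC[C@@H]1[C@@]2(C)CC/C(=N\OCc3cn(-c4ccccc4C#N)nn3)C(C)(C)[C@@H]2CC[C@@]1(C)O`: 25100 nM
compound 2, `CC(C)=CCC/C(C)=C/CC/C(C)=C/CC[C@@H]1[C@@]2(C)CC/C(=N\OCc3cn(-c4cccc([N+](=O)[O-])c4)nn3)C(C)(C)[C@@H]2CC[C@@]1(C)O`: 17400 nM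
compound 3, `CC(C)=CCC/C(C)=C/CC/C(C)=C/CC[C@@H]1[C@@]2(C)C/C(=C\c3ccc(OCc4cn(-c5ccccc5C#N)nn4)cc3)C(=O)C(C)(C)[C@@H]2CC[C@@]1(C)O`: 25100 nM

Compound 1 and compound 2 share one core, and compound 2 differs from compound 1 by 3-nitrophenyl in place of 2-cyanophenyl on an aromatic nitrogen; in this assay that change gave a 1.4-fold lower number from compound 1 to compound 2 (0.16 log units; within the scatter). Compound 3 carries a second core, and the difference between the two cores is not broken down here; its number is level with compound 1 at the digits given and together with it the highest of the three. Compound 4, `CC(C)=CCC/C(C)=C/CC/C(C)=C/CC[C@@H]1[C@@]2(C)C/C(=C\c3ccc(OCc4cn(-c5cccc([N+](=O)[O-])c5)nn4)cc3)C(=O)C(C)(C)[C@@H]2CC[C@@]1(C)O`, applies the same change to the core of compound 3: 3-nitrophenyl in place of 2-cyanophenyl on an aromatic nitrogen. The place of the change is the same in both pairs, so the same small step is expected, and compound 4 is estimated at a 1.4-fold lower number from compound 3 to compound 4 (0.14 log units; within the scatter), that is about 18000 nM with a likely range of 9000 nM to 36000 nM. This expectation rests on compound 3, which gives 25100 nM, and on the earlier step of a 1.4-fold lower number from compound 1 to compound 2 (0.16 log units; within the scatter).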

Compound 4, half-maximal inhibitory concentration: 46400 nM
Compound 4: the middle estimate sits 2.6-fold (0.41 log units) below what was measured; measured number outside the range, above it.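

In this assay, putting 3-nitrophenyl in place of 2-cyanophenyl on the core of compound 3 gave a 1.8-fold higher number from compound 3 to compound 4 (0.27 log units; within the scatter), so the step seen on the other core did not repeat in the same direction. Set side by side, the two steps do not carry over from one core to the other as a single value: the same change on two cores in this assay, a 1.4-fold lower number (0.16 log units; within the scatter) from compound 1 to compound 2 and a 1.8-fold higher number (0.27 log units; within the scatter) from compound 3 to compound 4, 2.7-fold (0.43 log units) apart, beyond the scatter of two such steps. Each step alone stays within the scatter, however, so neither shows that the change by itself raises or lowers the number, and two pairs give no rule for the whole series.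

From the compounds shown here alone, it remains open whether other groups on that aromatic nitrogen, such as an aminophenyl or a benzyl, would differ between the two cores in the same way. Going by these compounds, it also remains open whether the gap between the steps would appear again in another cell line.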